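Quinoline sulfone series: halogen swap on the pendant aryl

This account rests on a few compounds, and the source may have more. Where it says the series, first, only, none or still open, it means among the compounds named here.

Compound 1 `O=S(=O)(c1cccc(F)c1)c1cnc2c(F)cccc2c1-c1ccc(Cl)cc1` gives 0.62 mL/min in an ADME assay on microsomes from liver (Homo sapiens) for metabolic stability, tested at 2.5 uM (a lower number here means slower removal, a higher number faster removal of the compound), and stands lowest of the three measured numbers, with compound 2 nearest and compound 3 furthest. Compound 2 `O=S(=O)(c1cc(F)cc(F)c1)c1cnc2c(F)cccc2c1-c1ccc(Cl)cc1` gives 0.73 mL/min and compound 3 `O=S(=O)(c1cc(Cl)cc(Cl)c1)c1cnc2c(F)cccc2c1-c1ccc(Cl)cc1` gives 0.78 mL/min. The measured steps are a 1.2-fold higher number from compound 1 to compound 2 (0.07 log units; within the scatter), a 1.3-fold higher number from compound 1 to compound 3 (0.10 log units; within the scatter) and a 1.1-fold higher number from compound 2 to compound 3 (0.03 log units; within the scatter); all three alter the aryl on the sulfonyl sulfur and all lie within the scatter. Compound 4 `O=S(=O)(c1cccc(F)c1)c1cnc2c(F)cccc2c1-c1ccc(F)cc1` differs from compound 1 elsewhere: fluoro in place of chloro on an aromatic carbon. Within the data shown here, no measured step touches that position, so the only guide is the flatness of the series so far. The step from compound 1 to compound 4 is therefore expected to be a 1.1-fold lower number from compound 1 to compound 4 (0.03 log units; within the scatter), within the scatter. Compound 4 is estimated at 0.58 mL/min, with a range of 0.35 mL/min to 0.95 mL/min.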

Compound 4, intrinsic clearance in a liver preparation (reported as CLH), per the amount of preparation that the assay uses: 0.19 mL/min
Compound 4: middle estimate off by 3.1-fold (0.48 log units), on the high side, and the stated range ends above it.
By their numbers in this assay, from the lowest: compound 4; then compounds 1, 2 and 3 (each within the scatter of the next).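

Among these compounds, the change from 4-chlorophenyl to 4-fluorophenyl gives a 3.3-fold lower number from compound 1 to compound 4 (0.51 log units; beyond the scatter) in this assay and is the only step so far beyond the scatter. This position on the aromatic ring of carbon only therefore responds to a single halogen swap, whereas the swaps on the aryl at the sulfonyl sulfur gave no step beyond the scatter. No measurement at hand accounts for the size of this step.

Going by these compounds, whether a nitrile, a methoxy group or an amine at this position would give a lower or higher number remains open. Also open, on these data alone, is whether the same swap gives a similar step with the 3,5-difluorophenyl or 3,5-dichlorophenyl on the sulfonyl sulfur.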